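Compound 4 and Its Expected Half-Life in Mouse Microsomes

This account rests on a few compounds, and the source may have more. Where it says the series, first, only, none or still open, it means among the compounds named here.

The three measured compounds share one core and differ only in the group on an aromatic nitrogen: compound 1 `CNC(=O)Nc1ccc(-c2nc(N3CC4CCC(C3)O4)c3cnn([C@H]4CC[C@@H](OC)CC4)c3n2)cc1` carries a 4-methoxycyclohexyl group, compound 2 `CNC(=O)Nc1ccc(-c2nc(N3CC4CCC(C3)O4)c3cnn(C(C)C)c3n2)cc1` an isopropyl, and compound 3 `CNC(=O)Nc1ccc(-c2nc(N3CC4CCC(C3)O4)c3cnn([C@H]4CC[C@@H](O)CC4)c3n2)cc1` a 4-hydroxycyclohexyl. In an in vitro ADME assay on microsomes (Mus musculus) for metabolic stability (on this read-out higher numbers stand for a longer-lived compound and lower numbers for a shorter-lived compound), compound 1 gives 0.283 h. For compound 2 the read-out in this assay is only a limit, > 0.5 h. Compound 3 likewise reaches only a limit in this assay, > 0.5 h. Compound 3 thus stands at the limit of > 0.5 h in this assay, at which 2 of the 3 values shown sit, and the step that the two limits leave unreadable from compound 2 to compound 3 cannot be sized. From compound 1 the steps are an at least 1.7-fold higher number from compound 1 to compound 2 (0.24 log units; that floor lies within the scatter) and an at least 1.7-fold higher number from compound 1 to compound 3 (0.24 log units; that floor lies within the scatter).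

Compound 4 `CNC(=O)Nc1ccc(-c2nc(N3CC4CCC(C3)O4)c3cnn(C4CCC(OC)(OC)CC4)c3n2)cc1` differs from compound 3 by a group of 10 heavy atoms (8 carbon, 2 oxygen; one six-membered non-aromatic ring of carbon only) in place of a group of 7 heavy atoms (6 carbon, 1 oxygen; one six-membered non-aromatic ring of carbon only), on an aromatic nitrogen. The step that bears on this change is an at least 1.7-fold higher number from compound 1 to compound 3 (0.24 log units; that floor lies within the scatter), where hydrogen replaces methyl on an oxygen on a saturated carbon; compound 4 moves the other way, its entering group having 0 hydrogen-bond donors and 2 hydrogen-bond acceptors where 4-hydroxycyclohexyl has 1 of each. A step back toward the number of compound 1 is therefore expected, an at least 1.6-fold lower number from compound 3 to compound 4 (0.22 log units; that floor lies within the scatter). Compound 4 is estimated at 0.3 h, within a range from 0.15 h to 0.6 h.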

Compound 4, half-life: 0.25 h
Estimate against measurement, compound 4: 1.2-fold (0.08 log units) above, and the stated range covers the measured number.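

In this assay the group of 10 heavy atoms on the aromatic nitrogen gives a number rather than a limit, and set against the 4-hydroxycyclohexyl the result is an at least 2.0-fold lower number from compound 3 to compound 4 (0.30 log units; that floor lies within the scatter). Set against the isopropyl, the result is of the same kind, an at least 2.0-fold lower number from compound 2 to compound 4 (0.30 log units; that floor lies within the scatter), so neither step is shown to exceed the scatter, and how large either one really is stays unknown: the limit of > 0.5 h in this assay, at which 2 of the 4 values shown sit. Set against the 4-methoxycyclohexyl, the result is a 1.1-fold lower number from compound 1 to compound 4 (0.05 log units; within the scatter), so this read-out does not tell the larger group on compound 4 from the group on compound 1.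

The compounds shown leave open how far compound 2 and compound 3 really lie from compound 1 and compound 4, and whether compound 2 and compound 3 differ from each other at all. They also leave open whether a plain cyclohexyl or a 4-aminocyclohexyl on the same nitrogen would read with compound 1 and compound 4 or would reach the limit seen for compound 2 and compound 3.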